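The compounds below may be only part of what the source reports. "The series", "measured", "known", "first", "only" and "open" are said of these compounds alone.

Of the compounds shown here, three built on related frameworks have been measured in an ADME assay for protein binding, using equilibrium dialysis, at pH 7.4, tested at 2 uM; a lower number here means a smaller unbound share, a higher number a larger unbound share of the compound. Compound 1 `CC(C)(C)C#Cc1cc(N(C(=O)[C@H]2CC[C@H](C)CC2)[C@H]2CC[C@H](Oc3cccnc3)CC2)c(C(=O)O)s1` gives 0.03 and compound 3 `CC(C)(C)C#Cc1cc(N(C(=O)[C@H]2CC[C@H](C)CC2)[C@H]2C[C@@H](Oc3cccnc3)C2)c(C(=O)O)s1` gives 0.04, two values within the scatter of each other. Compound 2 `CC(C)N(C(=O)C1CCCCC1)c1cc(C#CC(C)(C)C)sc1C(=O)O` gives 0.18, the highest of the three, and its gap to each of the others lies beyond the scatter. It is also the smallest of these molecules, so it is the natural starting point for a closely related compound.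

That relative is compound 4 `CC(C)N(C(=O)C1CCCCCC1)c1cc(C#CC(C)(C)C)sc1C(=O)O`, which has cycloheptyl in place of cyclohexyl on a carbonyl carbon, (cycloheptyl in place of cyclohexyl on a carbonyl carbon). Everything else stays the same, and the new ring adds no hydrogen-bond donors or acceptors.

For the measured compounds named here, no pair of measured compounds differs in only one place, so the data cannot show directly what such a swap does. The only hint is weak: the larger compound 1, at 0.03, sits lower than compound 2. A small downward move in this assay therefore seems more likely than an upward one, and it would probably stay within the scatter. The expected change is a 1.5-fold lower number from compound 2 to compound 4 (0.18 log units; within the scatter). For compound 4, the estimated unbound fraction is 0.12, with an expected range of 0.07 to 0.2.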

Compound 4, unbound fraction: 0.11
For compound 4 the middle estimate is 1.1-fold (0.04 log units) above the measured one; the range from low to high includes it.
By their numbers in this assay, from the lowest: compounds 1 and 3 (each within the scatter of the next); then compounds 4 and 2 (each within the scatter of the next).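

For the compounds shown here, compound 2 and compound 4 are the first pair here that differ in only one place, so this assay can now be read directly for this change on a carbonyl carbon whose other neighbours are an amide-type nitrogen. Cycloheptyl in place of cyclohexyl gives a 1.6-fold lower number from compound 2 to compound 4 (0.21 log units; within the scatter), and at this position the data therefore show no clear difference between the six-membered and the seven-membered carbon ring, neither of which has hydrogen-bond donors or acceptors. No measured property is available that would explain this result or link it to either ring.

As far as these compounds go, with only these two rings compared at this position, it remains open whether a smaller cyclopentyl ring, an open chain such as tert-butyl, or a ring carrying an amine or a hydroxyl group would move the unbound fraction beyond the scatter. From the compounds shown here alone, it also remains open whether the same swap would give a similar step on the frameworks of compound 1 and compound 3, which carry a different group on the amide-type nitrogen.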